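The source may report more compounds than this note shows. Statements on the series, on what has been measured and on what is new or still open speak of the compounds shown alone.

Compound 3 `COc1cc(N)c(Cl)cc1C(=O)CCC1CCN(CCNS(=O)(=O)c2ccc(N)c(Br)c2)CC1` gives the highest number of the three measured compounds in an assay on HEK293 cells for displacement of a labelled ligand from 5-hydroxytryptamine receptor 6 (Homo sapiens), with a stated time of 60 min, tested at 1 uM, in the presence of a further agent that is not named here (a higher number here means a stronger effect of the compound at the concentration tested, a lower number a weaker effect), with 85%. Its nearest neighbour is compound 2 `COc1ccc(S(=O)(=O)NCCN2CCC(CCC(=O)c3cc(Cl)c(N)cc3OC)CC2)cc1Br`, which gives 72% in this assay, and the furthest is compound 1 `COc1cc(N)c(Cl)cc1C(=O)CCC1CCN(CCNS(=O)(=O)c2cc(Br)ccc2Br)CC1`, which gives 52% in this assay. Both steps towards compound 3 lie beyond the scatter: a number 13 percentage points higher from compound 2 to compound 3 (beyond the scatter), and a number 33 percentage points higher from compound 1 to compound 3 (beyond the scatter).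

Compound 4 `COc1ccc(S(=O)(=O)NCCN2CCC(CCC(=O)c3cc(Cl)c(N)cc3OC)CC2)c(OC)c1` differs from compound 3 in one place: 2,4-dimethoxyphenyl in place of 4-amino-3-bromophenyl on a sulfonyl sulfur. Within the data shown here, two measured steps bear on this. The step of a number 13 percentage points higher from compound 2 to compound 3 (beyond the scatter) shows what the amino brought over a methoxy; compound 4 gives that amino up. The step of a number 33 percentage points higher from compound 1 to compound 3 (beyond the scatter) shows how much the 4-amino-3-bromophenyl gained over the 2,5-dibromophenyl; compound 4 keeps neither the amino nor the bromine. A drop beyond the scatter is therefore expected in this assay, of about the size seen between compound 2 and compound 3, possibly somewhat more, since the loss of the bromine is not covered by any measured step. The expected change is a number 23 percentage points lower from compound 3 to compound 4 (beyond the scatter), so compound 4 is estimated at 62%, within a range from 42% to 80%.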

Compound 4, a percentage reported as inhibition, at one concentration (the size of the read-out at that concentration, not a potency): 45%
Compound 4: middle estimate off by 17 percentage points, on the high side; the range from low to high includes it.
By their numbers in this assay, from the lowest: compounds 4 and 1 (each within the scatter of the next); then compound 2; then compound 3.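

Among these compounds, measured this assay, the result shows that this place on a sulfonyl sulfur tolerates a methoxy-bearing ring far less well than compound 2 alone suggested: the 2,4-dimethoxyphenyl gives a much larger loss against the 4-amino-3-bromophenyl (a number 40 percentage points lower from compound 3 to compound 4 (beyond the scatter)) than the single amino-for-methoxy swap did, and it also falls short of the 3-bromo-4-methoxyphenyl (a number 27 percentage points lower from compound 2 to compound 4 (beyond the scatter)). Two rings with entirely different substituents, 2,4-dimethoxyphenyl and 2,5-dibromophenyl, cannot be told apart here (a number 7 percentage points lower from compound 1 to compound 4 (within the scatter)), so the pattern of substitution matters and not the mere presence of methoxy or bromine. Nothing measured here accounts for these differences.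

Which of the two methoxy groups of compound 4 carries the loss stays open. So does whether a phenyl bearing only the amino, or a hydroxyl or nitrile in place of the bromine, would keep the read-out of compound 3.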